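The source may hold more compounds than are shown below. What is called first, only, known or untested is meant among the compounds shown, and "the series" means these compounds.

Measured compounds:
compound 1, `COc1ccc(N(C)c2nc(C)nc3ccccc23)cc1C(=O)OCCC[Se]C#N`, 854 nM
compound 2, `Cc1nc(N(C)c2ccc([Se]C#N)c(F)c2)c2ccccc2n1`, 13 nM
compound 3, `C[Se]c1ccc(N(C)c2nc(C)nc3ccccc23)cc1Cl`, 3 nM

The three compounds were tested in a functional assay on LoVo cells (Homo sapiens) for inhibition, read by MTT assay, with a stated time of 48 h; on this read-out higher numbers stand for weaker inhibition and lower numbers for stronger inhibition. Compound 1 gives the highest of the three numbers. Compound 2 gives a markedly lower number, and compound 3 a lower one still, both gaps lying beyond the usual scatter of repeated measurements. Compound 1 is therefore the weakest inhibitor among the three on this read-out.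

Compound 4, `COc1ccc(N(C)c2nc(C)nc3ccccc23)cc1OCCCC[Se]C#N`, differs from compound 1 at one spot. a group of 8 heavy atoms (5 carbon, 1 nitrogen, 1 oxygen, 1 selenium; no ring) in place of a group of 9 heavy atoms (5 carbon, 1 nitrogen, 2 oxygen, 1 selenium; no ring), on an aromatic carbon Put simply, a chain bearing a selenium-bound nitrile is kept, but the link that holds it to the ring changes and the chain grows by one carbon.

Among the compounds with values here, no measured pair shows what such a change does in this assay, so the expectation rests on compound 1 alone. The step from compound 1 to compound 4 is expected to be small, within or near the scatter, with perhaps a slight lean toward a lower number: a 1.4-fold lower number from compound 1 to compound 4 (0.15 log units; within the scatter). Compound 4 is accordingly estimated at 600 nM, within a range of 150 nM to 2500 nM.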

Compound 4, half-maximal inhibitory concentration: 882 nM
Beside the measured number, compound 4's estimate is 1.5-fold (0.17 log units) below it; the range from low to high includes it.
By their numbers in this assay, from the lowest: compound 3; then compound 2; then compounds 1 and 4 (each within the scatter of the next).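

In this assay, within the data shown here, the step of a 1.0-fold higher number from compound 1 to compound 4 (0.01 log units; within the scatter) lies within the scatter, so this is the first direct look at a change at this position, the aromatic carbon ortho to a methoxy group. Replacing the group of 9 heavy atoms, which holds a carbonyl, with the group of 8 heavy atoms changes the link to the ring and lengthens the chain, yet the two compounds cannot be told apart on this read-out. No supporting measurement explains this result.

Both groups end in the selenium-bound nitrile, so the compounds shown leave open what that end contributes and whether an amine or a carboxylic acid there would read the same. They also leave open how a shorter or longer chain on the same link would read.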